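A Chain-End Swap Measured Against Three Limits

The source may report more compounds than this note shows. Statements on the series, on what has been measured and on what is new or still open speak of the compounds shown alone.

Compound 1 `N#CNC(=N)NCCCn1nc(-c2ccccc2)ccc1=O` was tested in a functional assay on the whole organism (stomach) with Rattus norvegicus as the target; on this read-out higher numbers stand for an effect only at larger amounts of compound and lower numbers for an effect already at smaller amounts. In this assay compound 1 gives > 100 mg/kg, which is a limit of the assay rather than a number. Compound 2 `C/N=C(\S)NCCCCn1nc(C)ccc1=O` was tested in the same way, and in this assay compound 2 gives > 100 mg/kg, again a limit. Compound 3 `C/N=C(/NC#N)NCCCCn1nc(C)ccc1=O` likewise, and in this assay compound 3 gives > 100 mg/kg, also a limit. All three values shown therefore sit at the limit of > 100 mg/kg in this assay, at which 3 of the 3 values shown sit, so compound 1 cannot be placed relative to the others beyond sharing that limit.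

Compound 4 `CC/N=C(\S)NCCCCCn1nc(-c2ccccc2)ccc1=O` is not yet measured. It differs from compound 1 by a group of 8 heavy atoms (5 carbon, 2 nitrogen, 1 sulfur; no ring) in place of a group of 6 heavy atoms (2 carbon, 4 nitrogen; no ring), on a saturated chain carbon, three bonds along the chain from an aromatic nitrogen. Among the compounds with values here, the only measured step that touches a related change is a step that the two limits leave unreadable from compound 2 to compound 3, and since both ends of that step are limits its size cannot be read. Within the data shown here, no measured step therefore gives a direction or size for the change from compound 1 to compound 4, and the three limits offer no footing for expecting an effect within the tested range.

On that basis compound 4 is expected to give about 100 mg/kg in this assay, with a range from 40 mg/kg to 300 mg/kg. The step from compound 1 to compound 4 that this estimate implies, a number no higher from compound 1 to compound 4 (the limit leaves the size open), is expected to be no real change, and a limit is expected to be the most likely outcome.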

Compound 4, dose for half-maximal effect: 51.8 mg/kg
Compound 4: the middle estimate sits 1.9-fold (0.29 log units) above what was measured; low and high end bracket the measured number.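

Compound 4 is the only compound shown that gives a number rather than a limit in this assay, so an effect within the tested range is possible on the core of compound 1 when the group on this saturated chain carbon is exchanged. On these data alone, the exchange gives an at least 1.9-fold lower number from compound 1 to compound 4 (0.28 log units; that floor lies within the scatter), so the direction can be stated only as far as that floor allows, and the real size remains open. The step between the two other compounds cannot be read, which leaves this single number with no other readable step to compare it with: the limit of > 100 mg/kg in this assay, at which 3 of the 4 values shown sit.

The entering group differs from the leaving one in both its carbon count and its sulfur, and the compounds shown cannot separate these two differences or say which of them goes with the number for compound 4. They also leave open how an amine or a carboxylic acid at the end of the chain, or a longer chain carrying the same sulfur-bearing end group, would read in this assay.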